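Quinolin-2-yl for benzimidazol-2-yl at the ring-amine methylene

The compounds below may be only part of what the source reports. "The series", "measured", "known", "first", "only" and "open" are said of these compounds alone.

Measured so far in an assay on membranes from CHO-K1 cells for displacement of a labelled ligand from 5-hydroxytryptamine receptor 7 (Homo sapiens), read by scintillation counting; a lower number here means a stronger inhibitor, a higher number a weaker inhibitor:
compound 1 `COc1cc2ncnc(N3CCC(CN4CCN(c5cccc(Cl)c5)CC4)C3)c2cc1OC` gives 372 nM
compound 2 `COc1cc2ncnc(N3CCC(CN4CCN(c5cccc(Cl)c5Cl)CC4)C3)c2cc1OC` gives 347 nM
compound 3 `COc1cc2ncnc(N3CCN(Cc4nc5ccccc5[nH]4)CC3)c2cc1OC` gives > 1000 nM

Compound 3 sits at the weak end of the numbers shown. Its value in this assay is a limit of the assay and not a number, (the limit of > 1000 nM in this assay, at which 1 of the 3 values shown sits); the true inhibition constant of compound 3 is not known beyond that.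

Compound 4 `COc1cc2ncnc(N3CCN(Cc4ccc5ccccc5n4)CC3)c2cc1OC` is not yet measured. The change from compound 3 is quinolin-2-yl in place of 1H-benzimidazol-2-yl on a saturated chain carbon bound to an amine nitrogen in a ring.

Among the compounds with values here, the only measured step with one change, a 1.1-fold lower number from compound 1 to compound 2 (0.03 log units; within the scatter), concerns a chloro on the aryl piperazine of compound 1 and does not touch the group that is exchanged here. Within the data shown here, no measured step therefore bears on the change from compound 3 to compound 4, and its direction cannot be read from the data. Compound 3 is known only as a limit, so the step that the limit leaves unreadable from compound 3 to compound 4 is an expectation of where compound 4 may fall, with a wide range. Compound 4 is expected to give about 1500 nM in this assay, between 300 nM and 8000 nM.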

Compound 4, inhibition constant: > 1000 nM
Compound 4: only a limit was reported; the forecaster's own chance of this, stated with the estimate: 55%; the middle value does not contradict the limit.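

No step from compound 3 to compound 4 can be read in this assay, because both values are limits of the assay and not numbers: the limit of > 1000 nM in this assay, at which 2 of the 4 values shown sit.

Still open, as far as these compounds go, is whether quinolin-2-yl or 1H-benzimidazol-2-yl gives the stronger inhibitor, and what the true inhibition constant of either compound is.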